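Lactam to cyclic urea on the side chain of compound 2

The source may report more compounds than this note shows. Statements on the series, on what has been measured and on what is new or still open speak of the compounds shown alone.

Measured so far in a functional assay on CHO cells for antagonist activity at prostaglandin E2 receptor EP3 subtype (Homo sapiens), read by cAMP accumulation; on this read-out lower numbers stand for stronger inhibition and higher numbers for weaker inhibition:
- compound 1 `CCn1ncc2c(F)cc(-c3ccc(C(CC)(CC)c4nnc[nH]4)c(=O)[nH]3)cc21`: 29 nM
- compound 2 `CC(C)C(c1ccc(-c2ccc3cccc(F)c3c2)[nH]c1=O)N1CCCCC1=O`: 40 nM
- compound 3 `CCC(CC)(c1nnc[nH]1)c1ccc(-c2ccc3cccc(F)c3c2)[nH]c1=O`: 36 nM

Compound 2 has the largest of the three numbers, but the gaps to compound 3 and to compound 1 are both within the usual scatter, so the three compounds read as equivalent on this assay. Among the compounds with values here, no pair among them differs in only one place, so no single step can be isolated from the measured set.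

Compound 4 `CC(C)C(c1ccc(-c2ccc3cccc(F)c3c2)[nH]c1=O)N1CCNC1=O` is the next compound to be run. It differs from compound 2 as follows: 2-oxoimidazolidin-1-yl in place of 2-oxopiperidin-1-yl on a saturated chain carbon bound to an aromatic carbon and a saturated chain carbon. The change keeps the carbonyl and the saturated ring attached through nitrogen, shrinks the ring by one member, and brings in a hydrogen-bond donor that compound 2 lacks.

Within the data shown here, with no measured step of this type available, the expectation rests on the closeness of the three numbers so far: the series tolerates quite different groups on that chain carbon without moving beyond the scatter. A step of modest size, if any, is expected in a 1.4-fold higher number from compound 2 to compound 4 (0.14 log units; within the scatter), leaning toward a weaker number but not clearly beyond the scatter. Compound 4 is therefore estimated at 55 nM, with a range from 20 nM to 160 nM.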

Compound 4, half-maximal inhibitory concentration: 28 nM
Beside the measured number, compound 4's estimate is 2.0-fold (0.29 log units) above it; low and high end bracket the measured number.
By their numbers in this assay, from the lowest: compounds 4, 1, 3 and 2 (each within the scatter of the next).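

In this assay, 2-oxoimidazolidin-1-yl in place of 2-oxopiperidin-1-yl on the saturated chain carbon gives a 1.4-fold lower number from compound 2 to compound 4 (0.15 log units; within the scatter), so the two groups read as equivalent on this assay. This is the only step among the compounds shown that changes a single place, and it gives direct evidence for what the earlier comparisons could only suggest: at this position, a five-membered cyclic urea carrying a hydrogen-bond donor and a six-membered lactam without one are interchangeable within the scatter. No supporting data bear on why the read-out holds across this change.

Ring size and the hydrogen-bond donor change together in this step, so their separate contributions remain unresolved; 2-oxopyrrolidin-1-yl would pair the five-membered ring with no donor, and 3-methyl-2-oxoimidazolidin-1-yl would cap the donor while keeping the cyclic urea. The limits of tolerance at this position also remain open, since the step covers only neutral cyclic carbonyl groups and leaves a piperidine without the carbonyl, a carboxylic acid or an open-chain amide untested by the compounds shown.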